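Swapping methyl for a trifluoromethylphenyl ring on the shared core

A few compounds are considered here, and "the series" means these few. Any claim that something is new, unique, unknown or untested is made for them only; others in the source may bear on it.

Compound 2 `CC1C(=O)N(C)c2cnc(Nc3ccc(S(N)(=O)=O)cc3)nc2N1C` gives 313 nM in an assay on Sf9 cells for inhibition of serine/threonine-protein kinase 4 (Homo sapiens), read by luminescence and ADP-Glo, with a stated time of 1 h, in the presence of a further agent that is not named here (on this read-out higher numbers stand for weaker inhibition and lower numbers for stronger inhibition), the highest number among the three measured compounds. Compound 1 `CN1C(=O)C(C2CC2)N(C)c2nc(Nc3ccc(S(N)(=O)=O)cc3)ncc21` gives 136 nM in this assay, and compound 3 `CN1C(=O)C(c2ccccc2Cl)N(C)c2nc(Nc3ccc(S(N)(=O)=O)cc3)ncc21` gives 129 nM. Compound 4 `CN1C(=O)C(c2ccccc2C(F)(F)F)N(C)c2nc(Nc3ccc(S(N)(=O)=O)cc3)ncc21` differs from compound 2 in one place: 2-(trifluoromethyl)phenyl in place of methyl on a saturated ring carbon. The step that bears most on this change is a 2.4-fold lower number from compound 2 to compound 3 (0.38 log units; beyond the scatter), where a six-membered aromatic ring likewise took the place of the methyl. The step of a 2.3-fold higher number from compound 1 to compound 2 (0.36 log units; beyond the scatter) points the same way, while a 1.1-fold lower number from compound 1 to compound 3 (0.02 log units; within the scatter) shows compound 1 and compound 3 close together. A step of similar size towards a lower number is therefore expected for compound 4, estimated at a 2.1-fold lower number from compound 2 to compound 4 (0.32 log units; beyond the scatter). Compound 4 is expected to give 150 nM, in a range from 60 nM to 400 nM.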

Compound 4, half-maximal inhibitory concentration: 56 nM
Compound 4: the middle estimate sits 2.7-fold (0.43 log units) above what was measured; the whole stated range lies above it.
By their numbers in this assay, from the lowest: compound 4; then compounds 3 and 1 (each within the scatter of the next); then compound 2.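

Among these compounds, at this saturated ring carbon, 2-(trifluoromethyl)phenyl gives the lowest number so far: in place of methyl it gives a 5.6-fold lower number from compound 2 to compound 4 (0.75 log units; beyond the scatter) and in place of cyclopropyl it gives a 2.4-fold lower number from compound 1 to compound 4 (0.39 log units; beyond the scatter). The aromatic ring alone does not set this level, since trifluoromethyl in place of chloro on that ring gives a 2.3-fold lower number from compound 3 to compound 4 (0.36 log units; beyond the scatter). Nothing available here accounts for these steps. Still open, going by these compounds, is whether that ring would hold this level with methoxy or a nitrile in place of trifluoromethyl. Also open, on these data alone, is how an amine on the saturated ring carbon would compare.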